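Ethoxycarbamoyl in place of the furan-bearing amide

The source may hold more compounds than are shown below. What is called first, only, known or untested is meant among the compounds shown, and "the series" means these compounds.

In a functional assay on HCT-116 cells (Homo sapiens) for inhibition, read by luminescence and CellTiter-Glo, with a stated time of 72 h (on this read-out lower numbers stand for stronger inhibition and higher numbers for weaker inhibition), compound 1 `Cc1cc2c(NS(C)(=O)=O)cccc2n1-c1nc2c(c(NCc3cccc(O)c3)n1)CCC2` gives 800 nM, compound 2 `C=CC(=O)Nc1cccc2c1cc(C)n2-c1nc2c(c(NCc3cccc(O)c3)n1)CCC2` gives 1200 nM and compound 3 `Cc1cc2c(NC(=O)c3ccco3)cccc2n1-c1nc2c(c(NCc3cccc(O)c3)n1)CCC2` gives 1200 nM. Compound 3 stands level with compound 2 at the digits shown, and all three compounds lie within the scatter of one another.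

Compound 4 `CCONC(=O)c1cccc2c1cc(C)n2-c1nc2c(c(NCc3cccc(O)c3)n1)CCC2`, not yet measured, carries ethoxycarbamoyl in place of ((furan-2-yl)carbonyl)amino on an aromatic carbon.

For the measured compounds named here, three measured steps bear on this change, though only indirectly: a 1.5-fold higher number from compound 1 to compound 2 (0.18 log units; within the scatter), a 1.5-fold higher number from compound 1 to compound 3 (0.18 log units; within the scatter) and no change at the digits printed from compound 2 to compound 3 (within the scatter). Each stays within the scatter, but each exchanges a group on a nitrogen while the aromatic carbon keeps that nitrogen. Going by the values given here, no measured compound carries ethoxycarbamoyl, so the range is kept wide.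

The step expected in this assay is no change at the digits printed from compound 3 to compound 4 (within the scatter), with none expected beyond the scatter. For compound 4 the estimated value is 1200 nM, with an expected range of 400 nM to 3500 nM.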

Compound 4, half-maximal inhibitory concentration: 600 nM
Compound 4: middle estimate off by 2.0-fold (0.30 log units), on the high side; measured number inside the range.
By their numbers in this assay, from the lowest: compounds 4, 1, 2 and 3 (each within the scatter of the next).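

Replacing the amide-type groups at this aromatic carbon with ethoxycarbamoyl in this assay gives three steps: (a 2.0-fold lower number from compound 3 to compound 4 (0.30 log units; within the scatter)), (a 2.0-fold lower number from compound 2 to compound 4 (0.30 log units; within the scatter)) and (a 1.3-fold lower number from compound 1 to compound 4 (0.12 log units; within the scatter)). The earlier steps shown here only exchanged groups on a nitrogen held by the aromatic carbon, whereas these show that a group joined through its carbonyl carbon, with no ring, also stays within the scatter of the three nitrogen-linked groups. Nothing available explains these numbers.

As far as these compounds go, whether a longer chain on the ethoxycarbamoyl oxygen, a carboxylic acid or a primary amine at this carbon would move the number beyond the scatter remains open. With every compound shown within the scatter of the next, the series also does not yet show how much this position matters to the read-out.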